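Dropping the methoxy group: from compound 3 to compound 4

The source may hold more compounds than are shown below. What is called first, only, known or untested is meant among the compounds shown, and "the series" means these compounds.

Measured so far:
- compound 1, `CC(Oc1nc2c(cnn2C)c(=O)n1-c1ccccc1)c1ccccc1`: 600 nM
- compound 2, `CC(Sc1nc2c(cnn2C)c(=O)n1-c1ccccc1)c1cccc(F)c1`: 128 nM
- compound 3, `COc1cccc(C(C)Sc2nc3c(cnn3C)c(=O)n2-c2ccccc2)c1`: 174 nM

All three share one core and differ only in the group hanging off it. In an assay on isolated protein for inhibition of Retinaldehyde dehydrogenase 3 (Homo sapiens) (on this read-out higher numbers stand for weaker inhibition and lower numbers for stronger inhibition), compound 3 gives 174 nM, the second highest of the three numbers. Compound 2 sits nearest, and the step of a 1.4-fold higher number from compound 2 to compound 3 (0.13 log units; within the scatter) shows that swapping one group for the other on that aromatic carbon changed little. The values that differ most from those of compound 3 are those of compound 1, which gives 600 nM in this assay.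

Compound 4, `CC(Sc1nc2c(cnn2C)c(=O)n1-c1ccccc1)c1ccccc1`, has not yet been measured. The change from compound 3 is hydrogen in place of methoxy on an aromatic carbon. Among the compounds with values here, only the step from compound 2 to compound 3 bears on it, and that step stayed within the scatter, so the group on that ring seems to matter little when exchanged; whether removing it altogether matters is untested. A small step of a 1.1-fold higher number from compound 3 to compound 4 (0.06 log units; within the scatter) in this assay is therefore expected. Compound 4 is estimated at 200 nM, with a range from 90 nM to 450 nM.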

Compound 4, half-maximal inhibitory concentration: 73 nM
The estimate for compound 4 lay 2.7-fold (0.44 log units) above the measured number, outside the stated range (below it).
By their numbers in this assay, from the lowest: compounds 4, 2 and 3 (each within the scatter of the next, the first and the last beyond it); then compound 1.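

Exchanging one group for another on this aromatic carbon had looked almost irrelevant, but removing the group altogether registers in this assay: a 2.4-fold lower number from compound 3 to compound 4 (0.38 log units; beyond the scatter) is modest, yet it lies beyond the scatter. The change from 3-methoxyphenyl to phenyl therefore matters at this position, and the lower number, meaning stronger inhibition, lies on the phenyl side. The comparison with fluoro is less decisive, since a 1.8-fold lower number from compound 2 to compound 4 (0.24 log units; within the scatter) stays within the scatter, so hydrogen and fluoro cannot be told apart on this read-out.

As far as these compounds go, it remains open whether an amine or a carboxylic acid on this same ring carbon would give a number closer to that of compound 3 or compound 4. No measurement at hand accounts for the gap between methoxy and hydrogen.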